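Methoxy count on the pendant aryl ring and potency

The source may hold more compounds than are shown below. What is called first, only, known or untested is meant among the compounds shown, and "the series" means these compounds.

Measured so far:
compound 1, `COc1cc(C(=O)/C=C/c2cc(-c3cc(OC)c(OC)c(OC)c3)n3nc(-c4ccccc4)cc3n2)cc(OC)c1OC`, 20500 nM
compound 2, `COc1ccc(-c2cc(/C=C/C(=O)c3cc(OC)c(OC)c(OC)c3)nc3cc(-c4ccccc4)nn23)cc1OC`, 7200 nM
compound 3, `COc1ccc(-c2cc(/C=C/C(=O)c3ccccc3)nc3cc(-c4ccccc4)nn23)cc1`, 8600 nM

All numbers come from a functional assay on A549 cells (Homo sapiens) for antiproliferative activity, read by MTT assay, with a stated time of 24 h; on this read-out higher numbers stand for weaker inhibition and lower numbers for stronger inhibition. Compound 2 and compound 3 differ in more than one place; the difference between the two cores is not broken down here, and their values in this assay lie within the scatter of each other. From compound 2 to compound 1 the change is methoxy in place of hydrogen on an aromatic carbon, and it gives a 2.8-fold higher number from compound 2 to compound 1 (0.45 log units; beyond the scatter).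

Compound 4, `COc1ccc(-c2cc(/C=C/C(=O)c3ccccc3)nc3cc(-c4ccccc4)nn23)cc1OC`, has not been measured. From compound 3 it carries methoxy in place of hydrogen on an aromatic carbon, the same kind of change, though here the entering group is not meta to a second methoxy group. The step is expected to run in the same direction, a 1.7-fold higher number from compound 3 to compound 4 (0.24 log units; within the scatter), because a 2.8-fold higher number from compound 2 to compound 1 (0.45 log units; beyond the scatter) was beyond the scatter. Compound 4 is therefore expected at 15000 nM, plausibly between 6000 nM and 38000 nM.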

Compound 4, half-maximal inhibitory concentration: 10700 nM
Compound 4: middle estimate off by 1.4-fold (0.15 log units), on the high side, within the range that was stated.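

In this assay, methoxy in place of hydrogen, 4-methoxyphenyl to 3,4-dimethoxyphenyl, gives a 1.2-fold higher number from compound 3 to compound 4 (0.09 log units; within the scatter), and phenyl in place of 3,4,5-trimethoxyphenyl on the carbonyl carbon gives a 1.5-fold higher number from compound 2 to compound 4 (0.17 log units; within the scatter). Set beside the earlier methoxy step, the new one cannot be told apart from it: the same change on two cores in this assay, a 2.8-fold higher number (0.45 log units; beyond the scatter) from compound 2 to compound 1 and a 1.2-fold higher number (0.09 log units; within the scatter) from compound 3 to compound 4, 2.3-fold (0.36 log units) apart, within the scatter of two such steps. For the compounds shown here, this shows no demonstrated dependence on the core, but it does not show that the change carries over, since only one of the two steps stands clear of the scatter and two pairs are a thin basis.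

As far as these compounds go, whether a hydroxy group, an amine or a longer chain such as ethoxy in place of the entering methoxy would give a readable step remains open. So does whether either step holds on other cell lines.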